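The source may hold more compounds than are shown below. What is called first, only, known or untested is meant among the compounds shown, and "the series" means these compounds.

Working notes on the chalcone series

Three compounds have numbers in a functional assay on MCF-10A cells (Homo sapiens) for inhibition (on this read-out higher numbers stand for weaker inhibition and lower numbers for stronger inhibition), so far. Compound 1 `O=C(/C=C/c1ccc(I)cc1)c1ccc(OCB(O)O)cc1` gives 38000 nM in this assay. Compound 3 `O=C(/C=C/c1ccccc1)c1ccc[nH]1` gives 63000 nM in this assay. Compound 2 `O=C(/C=C/c1ccc(F)c(Br)c1)c1ccc(B(O)O)cc1` gives 17000 nM in this assay, the lowest of the three numbers; its distances to compound 1 and to compound 3 are both beyond the usual scatter, so on the numbers shown compound 2 is the strongest inhibitor of the set. No pair among these three differs in only one place, so no single-point step is available as a guide for what a small change in the halogen pattern does in this assay.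

Compound 4 `O=C(/C=C/c1ccc(F)c(Cl)c1)c1ccc(B(O)O)cc1` is the next compound to be measured in this assay. It differs from compound 2 as follows: chloro in place of bromo on an aromatic carbon. The rest of the structure, including the boronic acid on the other ring and the fluoro group, is kept. With no measured step of this kind in hand, the expectation is for a change no larger than the scatter, in either direction, with a slight lean toward a higher number.

Compound 4 is therefore expected to give about 20000 nM in this assay, within a range of 8000 nM to 50000 nM, which would be an expected step of a 1.2-fold higher number from compound 2 to compound 4 (0.07 log units; within the scatter).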

Compound 4, half-maximal inhibitory concentration: 25000 nM
For compound 4 the middle estimate is 1.3-fold (0.10 log units) below the measured one; the measured number falls inside the stated range.
By their numbers in this assay, from the lowest: compounds 2, 4, 1 and 3 (each within the scatter of the next, the first and the last beyond it).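

In this assay, for the compounds shown here, chloro in place of bromo on an aromatic carbon, ortho to a fluoro group and meta to a large group, gives a 1.5-fold higher number from compound 2 to compound 4 (0.17 log units; within the scatter), the first step that changes only one place. At this position the read-out does not separate the two halogens, so the number of compound 2 does not rest on bromo specifically, and chloro serves equally well within the scatter. Nothing available bears on the reason for the size of this step.

Going by these compounds alone, the step covers only one halogen exchange at this one position, so whether a hydrogen, a methoxy group or an amine on the same carbon would keep the number in the same range remains open. Also open, as far as these compounds go, is what the fluoro group contributes, and whether a carboxylic acid in place of the boronic acid on the other ring would hold the number, as neither of those places is touched by the step in hand.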